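The source may report more compounds than this note shows. Statements on the series, on what has been measured and on what is new or still open speak of the compounds shown alone.

In a functional assay on A549 cells (Homo sapiens) for inhibition, read by CCK-8 assay, with a stated time of 72 h, tested at 10 uM (on this read-out higher numbers stand for more inhibition of growth at the one concentration tested and lower numbers for less inhibition of growth), compound 1 (`CN(C)C(=O)c1cc2cnc(Nc3ccc(NC(=O)C4(C(=O)Nc5ccc(Cl)cc5)CC4)cc3)nc2n1C1CCCC1`) reads 101% while compound 2 (`CN(C)C(=O)c1cc2cnc(Nc3ccc(NC(=O)C4(C(=O)Nc5ccccc5F)CC4)cc3)nc2n1C1CCCC1`) reads 88.6% and compound 3 (`COC(=O)c1cccc(NC(=O)C2(C(=O)Nc3ccc(Nc4ncc5cc(C(=O)N(C)C)n(C6CCCC6)c5n4)cc3)CC2)c1`) reads 91% on the same scale. Compound 3 thus lies within the scatter of both other compounds. Compound 4 (`CN(C)C(=O)c1cc2cnc(Nc3ccc(NC(=O)C4(C(=O)Nc5ccc(O)cc5)CC4)cc3)nc2n1C1CCCC1`) differs from compound 3 in one place (4-hydroxyphenyl in place of 3-(methoxycarbonyl)phenyl on an amide-type nitrogen). Three measured swaps on this same amide-type nitrogen bear on the change (a number 12.4 percentage points lower from compound 1 to compound 2 (beyond the scatter); a number 2.4 percentage points higher from compound 2 to compound 3 (within the scatter); a number 10 percentage points lower from compound 1 to compound 3 (within the scatter)). All are modest at most, although none involves a 4-hydroxyphenyl group, so no step beyond the scatter is expected in this assay here. The expected step is small (a number 3 percentage points lower from compound 3 to compound 4 (within the scatter)). For compound 4 the estimated value is 88% with an expected range from 70% to 103% on this read-out.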

Compound 4, percent growth inhibition at one concentration: 94.4%
Compound 4: the middle estimate sits 6.4 percentage points below what was measured; low and high end bracket the measured number.
By their numbers in this assay, from the lowest: compounds 2, 3, 4 and 1 (each within the scatter of the next, the first and the last beyond it).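

In this assay, a 4-hydroxyphenyl group on this amide-type nitrogen reads much like the groups already seen (a number 3.4 percentage points higher from compound 3 to compound 4 (within the scatter); a number 5.8 percentage points higher from compound 2 to compound 4 (within the scatter)). Hydroxy in place of chloro on an aromatic carbon also stays close (a number 6.6 percentage points lower from compound 1 to compound 4 (within the scatter)), so a hydrogen-bond donor on this ring is compatible with growth inhibition in these compounds. No measurement here explains these numbers.

Open, going by these compounds, is how a carboxylic acid or an amine on this ring would read. Also open, on these data alone, is whether a 3-hydroxyphenyl group would match the 4-hydroxyphenyl group.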